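This account rests on a few compounds, and the source may have more. Where it says the series, first, only, none or still open, it means among the compounds named here.

In a functional assay on the whole organism (strain albino) with Rattus norvegicus as the target, read by paw edema, with stated times of 1 h and 4 h, at a dose of 50 mg/kg by the oral route (on this read-out higher numbers stand for a stronger effect at the one dose given and lower numbers for a weaker effect), compound 1 `COc1ccc(Cl)cc1C(=O)Nc1ccc(C2=NN(C)C(c3ccccc3[N+](=O)[O-])C2)cc1` gives 99.5%. Compound 2 `COc1ccc(Cl)cc1C(=O)Nc1ccc(C2=NN(C)C(c3ccc([N+](=O)[O-])cc3)C2)cc1` gives 97.4% in this assay, and compound 3 `COc1ccc(Cl)cc1C(=O)Nc1ccc(C2=NN(c3ccccc3)C(c3ccccc3[N+](=O)[O-])C2)cc1` gives 88.4%. Compound 2 differs from compound 1 by 4-nitrophenyl in place of 2-nitrophenyl on a saturated ring carbon, a change that produced a number 2.1 percentage points lower from compound 1 to compound 2 (within the scatter). Compound 3 differs from compound 1 by phenyl in place of methyl on an amine nitrogen in a ring, which produced a number 11.1 percentage points lower from compound 1 to compound 3 (beyond the scatter); against compound 2, compound 3 is within the scatter.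

Compound 4 `COc1ccc(Cl)cc1C(=O)Nc1ccc(C2=NN(c3ccccc3)C(c3ccc([N+](=O)[O-])cc3)C2)cc1` has not been measured. It differs from compound 3 by 4-nitrophenyl in place of 2-nitrophenyl on a saturated ring carbon. This is the same kind of change as that from compound 1 to compound 2, though around the place the two cases differ: in compound 1 the saturated ring carbon sits next to the ring atom that bears a methyl group, while in compound 3 it sits next to the ring atom that bears a phenyl group. The two cores differ by phenyl in place of methyl on an amine nitrogen in a ring.

From compound 3 to compound 4 the expected step is a number 1.9 percentage points lower from compound 3 to compound 4 (within the scatter), resting on compound 1 and compound 2, where the same kind of change gave a number 2.1 percentage points lower from compound 1 to compound 2 (within the scatter). Compound 4 is therefore estimated at 86.5%, between 76% and 95%.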

Compound 4, a percentage reported as activity, at one dose (the size of the read-out at that dose, not a potency): 94.1%
Compound 4: the middle estimate sits 7.6 percentage points below what was measured, and the stated range covers the measured number.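

On the core of compound 3, 4-nitrophenyl in place of 2-nitrophenyl gave a number 5.7 percentage points higher from compound 3 to compound 4 (within the scatter) in this assay, and the change carries over from the core of compound 1 with no difference the data can detect: the same change on two cores in this assay, a number 2.1 percentage points lower (within the scatter) from compound 1 to compound 2 and a number 5.7 percentage points higher (within the scatter) from compound 3 to compound 4, 7.8 percentage points apart, within the scatter of two such steps. Phenyl in place of methyl on the ring nitrogen gave a number 3.3 percentage points lower from compound 2 to compound 4 (within the scatter), and this step likewise cannot be separated from its earlier counterpart: the same change on two cores in this assay, a number 11.1 percentage points lower (beyond the scatter) from compound 1 to compound 3 and a number 3.3 percentage points lower (within the scatter) from compound 2 to compound 4, 7.8 percentage points apart, within the scatter of two such steps. This shows only that neither change depends on the core by more than the scatter can reveal; each change rests on a single pair of cores and only one of the four steps lies beyond the scatter, so the steps are not shown to be equal, and the phenyl step is not shown to be a real effect on both cores.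

The compounds shown leave open how the read-out responds when an amine or a carboxylic acid stands in place of the nitro group, or a longer chain stands on the ring nitrogen. They also leave open whether compounds that cannot be told apart at this one dose would differ in potency.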